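Six-membered amine variation on the thiocarbonyl carbon

The compounds below may be only part of what the source reports. "The series", "measured", "known", "first", "only" and "open" are said of these compounds alone.

Measured so far:
- compound 1 `N/C(=N\NC(=S)N1CCOCC1)c1ccccn1`: 4700 nM
- compound 2 `Cc1cccc(/C(N)=N/NC(=S)N2CCSCC2)n1`: > 100000 nM (a limit of the assay, not a number)
- compound 3 `N/C(=N\NC(=S)N1CCSCC1)c1ccccn1`: 8800 nM

In a functional assay on MCF7 cells (Homo sapiens) for cytotoxicity, read by MTT assay, with a stated time of 72 h (on this read-out lower numbers stand for stronger inhibition and higher numbers for weaker inhibition), compound 3 gives 8800 nM. Two numbers exist in this assay; compound 1 sits nearest, and the step of a 1.9-fold higher number from compound 1 to compound 3 (0.27 log units; within the scatter) is within the scatter. For compound 2 this assay reports only a limit, > 100000 nM. The step of an at least 11-fold lower number from compound 2 to compound 3 (1.05 log units; beyond the scatter) is the one large move in the set, and it concerns a different place than the change below.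

Compound 4 `N/C(=N\NC(=S)N1CCCCC1)c1ccccn1` differs from compound 3 by piperidin-1-yl in place of thiomorpholin-4-yl on a thiocarbonyl carbon. Going by the values given here, the only measured step that bears on an exchange at this position is a 1.9-fold higher number from compound 1 to compound 3 (0.27 log units; within the scatter), which swapped one ring heteroatom for another and stayed within the scatter. A comparable swap is therefore expected to leave the number roughly where compound 3 stands, with no step beyond the scatter: a 1.2-fold lower number from compound 3 to compound 4 (0.07 log units; within the scatter). Compound 4 is estimated at 7500 nM, with a range from 2500 nM to 25000 nM.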

Compound 4, half-maximal inhibitory concentration: 8500 nM
Estimate against measurement, compound 4: 1.1-fold (0.05 log units) below; measured number inside the range.
By their numbers in this assay, from the lowest: compounds 1, 4 and 3 (each within the scatter of the next). At a limit, above all of these: compound 2.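

At the thiocarbonyl carbon in this assay, the change to piperidin-1-yl gives a 1.0-fold lower number from compound 3 to compound 4 (0.02 log units; within the scatter) and a 1.8-fold higher number from compound 1 to compound 4 (0.26 log units; within the scatter) and neither step separates the compounds. The earlier pair compared only a ring oxygen with a ring sulfur, whereas compound 4 carries neither and still stays within the scatter of both, so on this core neither atom is required for a number in this range. Nothing measured here accounts for this lack of separation.

Open at this position are a piperazine ring with a free nitrogen, a pyrrolidine ring and an open-chain dimethylamino group. Also open, going by these compounds, is whether the methyl on the aromatic carbon would act alike alongside piperidin-1-yl; compound 2 has only a limit, > 100000 nM and not a number.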